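Chloroacetamide in place of pivalamide on a sulfonate ester series

The source may report more compounds than this note shows. Statements on the series, on what has been measured and on what is new or still open speak of the compounds shown alone.

Compound 1 `CC(C)c1ccccc1OS(=O)(=O)c1cccc(NC(=O)C(C)(C)C)c1` and compound 2 `CC(C)c1ccccc1OS(=O)(=O)c1cccc(NC(=O)CCl)c1` share one core, while compound 3 `CC(C)c1ccccc1OS(=O)(=O)c1ccc(NC(=O)C(C)(C)C)cc1` and compound 4 `CC(C)c1ccccc1OS(=O)(=O)c1ccc(NC(=O)CCl)cc1` share another; compound 3 has the same atoms as compound 1, joined differently, and the difference between the two cores is not broken down here. In a functional assay on HT-29 cells (Homo sapiens) for antiproliferative activity, read by sulforhodamine B assay, with a stated time of 48 h (a higher number here means a weaker inhibitor, a lower number a stronger inhibitor), compound 1 gives 19000 nM. Compound 2 is changed at one point, (chloromethyl in place of tert-butyl on a carbonyl carbon), and in this assay compound 2 gives 4500 nM, so that the step of a 4.2-fold lower number from compound 1 to compound 2 (0.63 log units; beyond the scatter) is recorded. In this assay compound 3 gives 15000 nM, which lies within the scatter of the number for compound 1.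

Compound 4 has not yet been measured. It differs from compound 3 at one point, (chloromethyl in place of tert-butyl on a carbonyl carbon), and the place lines of the two changes agree word for word, so this is the same change in two pairs among the compounds shown. Since compound 3 stands close to compound 1 in this assay, the step for compound 4 is expected to resemble the earlier one. The expected step is a 4.2-fold lower number from compound 3 to compound 4 (0.62 log units; beyond the scatter), and it rests on compound 3 and compound 1 being within scatter of each other. For the measured compounds named here, compound 4 is therefore estimated at 3600 nM in this assay, with the likely range running from 1500 nM to 9000 nM, because a 4.2-fold lower number from compound 1 to compound 2 (0.63 log units; beyond the scatter) is the only guide available; compound 3 alone gives no second step to check against.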

Compound 4, half-maximal inhibitory concentration: 5600 nM
Estimate against measurement, compound 4: 1.6-fold (0.19 log units) below; low and high end bracket the measured number.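

In this assay, chloromethyl in place of tert-butyl on a carbonyl carbon again lowers the number, with a 2.7-fold lower number from compound 3 to compound 4 (0.43 log units; beyond the scatter), so the direction seen on the core of compound 1 is repeated on the core of compound 3. The sizes of the two steps cannot be told apart, and in these two pairs the change carries from one core to the other with much the same result: the same change on two cores in this assay, a 4.2-fold lower number (0.63 log units; beyond the scatter) from compound 1 to compound 2 and a 2.7-fold lower number (0.43 log units; beyond the scatter) from compound 3 to compound 4, 1.6-fold (0.20 log units) apart, within the scatter of two such steps. For the compounds shown here, this rests on only two pairs in a single assay, so it does not show that the change would carry to any further core, and it does not tell what lies behind the lower number.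

The compounds shown leave open whether the lower number goes with chloromethyl itself or would also follow from another group on the same carbonyl carbon, such as bromomethyl, plain methyl or a longer chain such as chloroethyl. They also leave open whether the same step would hold on a core other than these two, or in any assay other than this assay.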